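The source may hold more compounds than are shown below. What is called first, only, known or untested is meant among the compounds shown, and "the series" means these compounds.

Measured so far:
compound 1 `Cc1ccc(Oc2cc3c(cn2)nc(COc2cccc(C(=O)O)c2)n3C)cc1` — 6.8 10^-6 cm/s
compound 2 `Cn1c(COc2cccc(C(=O)O)c2)nc2ccc(Oc3ccccn3)cc21` — 2.2 10^-6 cm/s

Two compounds of the series have a number in an ADME assay for permeability, using PAMPA, with a stated time of 4 h; a lower number here means that the compound crosses the layer more slowly, a higher number that the compound crosses the layer faster. Compound 1 gives 6.8 10^-6 cm/s and compound 2 gives 2.2 10^-6 cm/s. Compound 2 stands at the lower of the two numbers; the gap to compound 1 lies beyond the scatter of the method. Among the compounds with values here, the two compounds differ in more than one place, so no single step connects them, and the pair says only what its two values show.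

The next compound, compound 3 `Cn1c(COc2cccc(C(=O)O)c2)nc2ccc(Oc3cc(Cl)ccn3)cc21`, differs from compound 2 in one place: chloro in place of hydrogen on an aromatic carbon — chloro in place of hydrogen on an aromatic carbon of the pyridin-2-yl ring, meta to a large group and opposite the ring nitrogen; read one bond further out, (pyridin-2-yl)oxy becomes (4-chloropyridin-2-yl)oxy.

Within the data shown here, no measured pair carries this change, so its size in this assay is not known from the data. A step in the upward direction, of modest size and possibly within the scatter, is expected for compound 3, and the estimate for compound 3 in this assay is 4 10^-6 cm/s, within 1.8 10^-6 cm/s to 9 10^-6 cm/s, which means an expected step of a 1.8-fold higher number from compound 2 to compound 3 (0.26 log units; within the scatter).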

Compound 3, apparent permeability: 10.3 10^-6 cm/s
Compound 3: the middle estimate sits 2.6-fold (0.41 log units) below what was measured; the whole stated range lies below it.
By their numbers in this assay, from the lowest: compound 2; then compounds 1 and 3 (each within the scatter of the next).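

Within the data shown here, compound 3 supplies the first single-place step: in this assay chloro in place of hydrogen on an aromatic carbon of the pyridin-2-yl ring, opposite the ring nitrogen, gives a 4.7-fold higher number from compound 2 to compound 3 (0.67 log units; beyond the scatter) and this lies beyond the scatter. The carbon opposite the ring nitrogen is therefore not a silent place in this read-out, as chloro alone, with no ring, no hydrogen-bond donor or acceptor and no net charge, moves the number by a step that can be read cleanly; compound 1 and compound 2 differ in more than one place and gave no such reading. The data shown offer no measurement that accounts for the step.

Open, on these data alone, is whether the step belongs to chloro itself or would recur with fluoro, methoxy, trifluoromethyl or a nitrile on the same carbon, and whether chloro on another carbon of the pyridin-2-yl ring gives a step of like size. As far as these compounds go, with a single pair carrying this change, its size in other members also remains unknown, including on the aryloxy ring of compound 1.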